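The source may hold more compounds than are shown below. What is called first, only, known or untested is meant among the compounds shown, and "the series" means these compounds.

Measured compounds and their values in an ADME assay on H1-HeLa cells (Homo sapiens) for cytotoxicity, read by MTT assay, with a stated time of 3 days; a higher number here means that more compound is tolerated, a lower number that less compound is tolerated:

Compound 1, `CCOC(=O)c1sc2cc(Oc3ccnc(C(=O)NC)c3)ccc2c1C`, gives 50900 nM.
Compound 2, `CNC(=O)c1cc(Oc2ccc3c(C)c(C(=O)OC(C)C)sc3c2)ccn1`, gives 18100 nM.
Compound 3, `CNC(=O)c1cc(Oc2ccc3ccc(C(=O)OC)cc3c2)ccn1`, gives 53500 nM.

Compound 3 stands highest of the three measured numbers in this assay, though its value and that of compound 1 lie within the usual scatter of each other, so no order between those two can be read. Compound 2 sits below both of them. The change from compound 1 to compound 2 is methyl in place of hydrogen on a saturated chain carbon bound to an oxygen next to a carbonyl group and a saturated chain carbon, and that step gave a 2.8-fold lower number from compound 1 to compound 2 (0.45 log units; beyond the scatter).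

Compound 4, `CCOC(=O)c1ccc2ccc(Oc3ccnc(C(=O)NC)c3)cc2c1`, has not yet been measured. It differs from compound 3 by methyl in place of hydrogen on a saturated chain carbon bound to an oxygen next to a carbonyl group. How the core of compound 3 differs from the core of compound 1 is not broken down here. The change from compound 3 to compound 4 is the same kind of change as that from compound 1 to compound 2, but not the same: in compound 1 the place is a saturated chain carbon bound to an oxygen next to a carbonyl group and a saturated chain carbon, whereas in compound 3 the place is a saturated chain carbon bound to an oxygen next to a carbonyl group only.

Among the measured compounds shown here, on the single earlier step of this kind, compound 4 is expected to sit somewhat below compound 3, at an estimated 1.8-fold lower number from compound 3 to compound 4 (0.25 log units; within the scatter). The estimate for compound 4 is 30000 nM, with a range from 12000 nM to 70000 nM, since one step on a different core is thin ground.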

Compound 4, half-maximal cytotoxic concentration: 20800 nM
The estimate for compound 4 lay 1.4-fold (0.16 log units) above the measured number, within the range that was stated.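

In this assay, replacing methoxycarbonyl with ethoxycarbonyl gave a 2.6-fold lower number from compound 3 to compound 4 (0.41 log units; beyond the scatter), so less of compound 4 is tolerated. Methyl in place of hydrogen on a saturated chain carbon bound to an oxygen next to a carbonyl group lowered the number to a matching degree on both cores, and the two steps cannot be told apart: the same change on two cores in this assay, a 2.8-fold lower number (0.45 log units; beyond the scatter) from compound 1 to compound 2 and a 2.6-fold lower number (0.41 log units; beyond the scatter) from compound 3 to compound 4, 1.1-fold (0.04 log units) apart, within the scatter of two such steps. Among the compounds shown here, this shows that the change carried over from the core of compound 1 to the core of compound 3 in this assay, even though the carbon in compound 1 also bears a saturated chain carbon and the one in compound 3 does not, but it rests on only two pairs and does not show that the same step would appear on any other core, in any other assay, or why the number falls.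

The compounds shown leave open whether a longer chain on the ester oxygen would lower the number further or whether the trend would level off. They also leave open how a carboxylic acid or a primary amide in place of the ester would stand on either core.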